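The source may report more compounds than this note shows. Statements on the series, on what has been measured and on what is new or still open speak of the compounds shown alone.

Compound 1 `CC1(O)CCCN(S(=O)(=O)c2cc(C(=O)Nc3ccc(F)c(Cl)c3)ccc2F)CC1` and compound 2 `CN1CCN(S(=O)(=O)c2cc(C(=O)Nc3ccc(F)c(Cl)c3)ccc2F)CC(O)C1` share one core and differ only in the group on the sulfonyl sulfur. In an ADME assay on HepG2 2.2.15 cells (Homo sapiens) for cytotoxicity, read by luminescence, with a stated time of 3 days (a higher number here means that more compound is tolerated, a lower number that less compound is tolerated), compound 1 gives 11000 nM, the lowest of the two numbers in hand, and compound 2 gives 31000 nM. Among the compounds with values here, the one step measured so far, a 2.8-fold higher number from compound 1 to compound 2 (0.45 log units; beyond the scatter), likewise exchanged the group on the sulfonyl sulfur, and is the only guide for a further change at that place. Compound 3 `O=C(Nc1ccc(F)c(Cl)c1)c1ccc(F)c(S(=O)(=O)N2CCCCC(O)C2)c1` is not yet measured in this assay and differs from compound 1 as follows: 3-hydroxyazepan-1-yl in place of 4-hydroxy-4-methylazepan-1-yl on a sulfonyl sulfur. Here the ring stays seven-membered and the donor and acceptor counts are unchanged, so a step no larger than that from compound 1 to compound 2, or none beyond the scatter, is expected in this assay. Compound 3 is estimated at 15000 nM, between 6000 nM and 40000 nM. The expected step is a 1.4-fold higher number from compound 1 to compound 3 (0.13 log units; within the scatter).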

Compound 3, half-maximal cytotoxic concentration: 15000 nM
Beside the measured number, compound 3's estimate shows no gap at the digits printed; the range from low to high includes it.
By their numbers in this assay, from the lowest: compounds 1 and 3 (each within the scatter of the next); then compound 2.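

In this assay the exchange of 4-hydroxy-4-methylazepan-1-yl for 3-hydroxyazepan-1-yl on the sulfonyl sulfur gives a 1.4-fold higher number from compound 1 to compound 3 (0.13 log units; within the scatter) and so leaves the number effectively unchanged, even though the methyl group is lost and the hydroxy group sits at a different ring position. The other comparison gives a 2.1-fold lower number from compound 2 to compound 3 (0.32 log units; beyond the scatter) and, taken with a 2.8-fold higher number from compound 1 to compound 2 (0.45 log units; beyond the scatter) as well, sets compound 2 apart from both azepan-1-yl compounds in this small set. No supporting data bear on the origin of these differences.

The compounds shown leave open whether the higher number of compound 2 goes with the second ring nitrogen or with the methyl group on it. Also open, from the compounds shown here alone, is how a morpholin-4-yl group or a carboxylic acid on the azepane ring would behave at this position.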